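Diyne series: vinyl-to-hydrogen change on two cores

The source may hold more compounds than are shown below. What is called first, only, known or untested is meant among the compounds shown, and "the series" means these compounds.

Measured so far:
- compound 1, `C=CCCCCCCCC#CC#CC(O)CC(C)=O`: 4.91 ug/mL
- compound 2, `CCCCCCCC#CC#CC(O)CC(C)=O`: 4.17 ug/mL
- compound 3, `C=CCCCCCCCC#CC#CCOCC(=O)OC`: reported only as a limit, > 30 ug/mL

All values come from a functional assay on A549 cells (Homo sapiens) for cytotoxicity; on this read-out higher numbers stand for an effect only at larger amounts of compound and lower numbers for an effect already at smaller amounts. Compound 1 and compound 2 share the hydroxy-ketone core and differ in one place, (hydrogen in place of vinyl on a saturated chain carbon, seven bonds along the chain from a triple-bonded carbon). The step is a 1.2-fold lower number from compound 1 to compound 2 (0.07 log units; within the scatter), so on this core the two compounds cannot be told apart.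

Compound 3 carries the ester core; how it differs from the core of compound 1 is not broken down here. In this assay, among the measured compounds shown here, compound 3 gives only a limit, > 30 ug/mL, and it is the one value sitting at the limit of > 30 ug/mL in this assay, at which 1 of the 3 values shown sits.

Compound 4, `CCCCCCCC#CC#CCOCC(=O)OC`, is not yet measured. It stands to compound 3 as compound 2 stands to compound 1: the difference is hydrogen in place of vinyl on a saturated chain carbon, seven bonds along the chain from a triple-bonded carbon, the same change at the same place. Since the measured step of a 1.2-fold lower number from compound 1 to compound 2 (0.07 log units; within the scatter) did not move the number, the expected step from compound 3 to compound 4 is likewise small, a step that the limit leaves unreadable from compound 3 to compound 4. Because compound 3 itself is only known as a limit > 30 ug/mL, the most likely outcome is that compound 4 is again reported at that limit rather than as a number. The estimate for compound 4 in this assay is 45 ug/mL, with the range 20 ug/mL to 120 ug/mL.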

Compound 4, concentration for half-maximal effect: > 30 ug/mL
Compound 4 was reported as a limit (the forecaster's own chance of this, stated with the estimate: 75%); the middle value does not contradict the limit.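

In this assay, compound 3 and compound 4 are both reported only as limits, so no step can be read between them: the limit of > 30 ug/mL in this assay, at which 2 of the 4 values shown sit.

The compounds shown leave open where compound 3 and compound 4 lie beyond that limit, and so whether hydrogen in place of vinyl matters as little on the core of compound 3 as on the core of compound 1.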